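The source may hold more compounds than are shown below. What is called first, only, known or untested is meant among the compounds shown, and "the series" means these compounds.

Among the compounds with values here, compound 2, `CCOc1ccccc1Nc1nc(SCc2ccc(C(F)(F)F)cc2)nc2ccccc12`, is one of two compounds measured in a functional assay on PC-3 cells (Homo sapiens) for cytotoxicity, read by MTT assay, with a stated time of 72 h; on this read-out lower numbers stand for stronger inhibition and higher numbers for weaker inhibition. In this assay compound 2 gives 26200 nM, the higher of the two numbers. The other is compound 1, `FC(F)(F)c1ccc(CSc2nc(Nc3ccccc3)c3ccccc3n2)cc1`, which in this assay gives 20000 nM. Compound 1 and compound 2 differ in one place, ethoxy in place of hydrogen on an aromatic carbon, and the step of a 1.3-fold higher number from compound 1 to compound 2 (0.12 log units; within the scatter) lies within the scatter.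

Compound 3, `Cc1ccccc1Nc1nc(SCc2ccc(C(F)(F)F)cc2)nc2ccccc12`, is the next compound in this series and has not been measured in this assay. It differs from compound 2 as follows: methyl in place of ethoxy on an aromatic carbon.

Within the data shown here, the only measured step that bears on this change is the one from compound 1 to compound 2, which put ethoxy at the same aromatic carbon without moving the number beyond the scatter. Swapping that ethoxy for methyl is therefore expected to leave the number roughly where it is; the step of a 1.2-fold lower number from compound 2 to compound 3 (0.08 log units; within the scatter) is expected to stay within the scatter. Compound 3 is estimated at 22000 nM, with a range from 9000 nM to 55000 nM.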

Compound 3, half-maximal inhibitory concentration: 36900 nM
For compound 3 the middle estimate is 1.7-fold (0.22 log units) below the measured one; the measured number falls inside the stated range.
By their numbers in this assay, from the lowest: compounds 1, 2 and 3 (each within the scatter of the next).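

In this assay, the aromatic carbon ortho to a large group now carries three different substituents: methyl in place of ethoxy gives a 1.4-fold higher number from compound 2 to compound 3 (0.15 log units; within the scatter), and methyl in place of hydrogen gives a 1.8-fold higher number from compound 1 to compound 3 (0.27 log units; within the scatter). The earlier pair set only ethoxy against hydrogen, whereas these steps add a second group, with fewer heavy atoms and no hydrogen-bond acceptor, and neither leaves the scatter, so hydrogen, methyl and ethoxy cannot be told apart at this position. No supporting data are available to explain why these three compounds read alike.

These three compounds leave open whether a group of another kind on this carbon, such as an amine or a carboxylic acid, would move the number beyond the scatter, and whether methyl or ethoxy would read the same on another carbon of that ring. Since the rest of the structure stays fixed throughout, they also leave open what would follow if a nitrile replaced the trifluoromethyl group of the shared core.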